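Adding an isopropyl group to a cyclohexyl side chain

A few compounds are considered here, and "the series" means these few. Any claim that something is new, unique, unknown or untested is made for them only; others in the source may bear on it.

Compound 1 `CCC1=C(C(=O)CCC2CCCCCC2)[C@H](c2ccc(O)c(Cl)c2)NC(=O)N1` and compound 2 `CCC1=C(C(=O)CC2CCCCC2)[C@H](c2ccc(O)c(Cl)c2)NC(=O)N1` share a core that carries a chlorinated phenol and a saturated side chain ending in a ketone. In an ADME assay on cells (Homo sapiens) for cytotoxicity (a higher number here means that more compound is tolerated, a lower number that less compound is tolerated), compound 1 gives only a limit of the assay, > 10000 nM. Compound 2 likewise gives only a limit in this assay, > 10000 nM. Within the data shown here, the single measured step, a step that the two limits leave unreadable from compound 1 to compound 2, cannot be read in size since (the limit of > 10000 nM in this assay, at which 2 of the 2 values shown sit). Compound 3 `CCC1=C(C(=O)CC2CCC(C(C)C)CC2)[C@H](c2ccc(O)c(Cl)c2)NC(=O)N1` differs from compound 2 by isopropyl in place of hydrogen on a saturated ring carbon; one bond further out, the change reads cyclohexyl to 4-isopropylcyclohexyl. Among the measured compounds shown here, the only step that bears on this change is the unreadable one from the ring swap, so no shift beyond the scatter in this assay is expected in either direction. The expected step that the limit leaves unreadable from compound 2 to compound 3 is therefore close to none. Compound 3 is estimated at 12000 nM, between 5000 nM and 30000 nM, most likely reported again only as a limit.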

Compound 3, half-maximal cytotoxic concentration: > 10000 nM
Compound 3 was reported as a limit; the forecaster's own chance of this, stated with the estimate: 70%; the middle value does not contradict the limit.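

Among these compounds, compound 1, compound 2 and compound 3 all end at a limit in this assay, so no step among them can be read in size: the limit of > 10000 nM in this assay, at which 3 of the 3 values shown sit. The compounds shown leave open at what concentration each harms the cells, and whether changing the side chain alters that concentration at all.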